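This account rests on a few compounds, and the source may have more. Where it says the series, first, only, none or still open, it means among the compounds named here.

Of the compounds shown here, three have so far been tested in a functional assay on DLD-1 cells (Homo sapiens) for antiproliferative activity, read by CellTiter-Glo, with a stated time of 72 h; on this read-out higher numbers stand for weaker inhibition and lower numbers for stronger inhibition. Compound 1 `CC1CCN(C2CCN(S(=O)(=O)c3cccc(Br)c3)CC2)CC1` gives 3.2 nM, the lowest number of the three and therefore the strongest inhibition seen. Compound 2 `Cc1ccc(-c2ccccc2S(=O)(=O)N2CCC(N3CCC(C)CC3)CC2)cc1` gives 366 nM, which is the second highest of the three numbers; the gap from compound 1 to compound 2 is very wide and well beyond the scatter. Compound 3 `Cc1cc(C)c(S(=O)(=O)NC2CCN(C3CCN(C)CC3)CC2)c(C)c1` gives 958 nM, a higher number than compound 2, and this gap too lies beyond the scatter, so compound 3 is the weakest of the three. None of these compounds differs from another in just one place, so no single-change step can be read from them.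

Compound 4 `COc1ccc(-c2ccccc2S(=O)(=O)N2CCC(N3CCC(C)CC3)CC2)cc1` is the next one to be measured. It differs from compound 2 in one place: methoxy in place of methyl on an aromatic carbon. For the measured compounds named here, no pair of measured compounds shows the effect of this exchange, so the expectation rests on the size of the change alone, which is small. The step in this assay from compound 2 to compound 4 is expected to be a 1.1-fold lower number from compound 2 to compound 4 (0.06 log units; within the scatter), most likely within the scatter. Compound 4 is therefore estimated at 320 nM, with a likely range from 120 nM to 900 nM.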

Compound 4, half-maximal inhibitory concentration: 1000 nM
The estimate for compound 4 lay 3.1-fold (0.49 log units) below the measured number; the whole stated range lies below it.
By their numbers in this assay, from the lowest: compound 1; then compound 2; then compounds 3 and 4 (each within the scatter of the next).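

In this assay, for the compounds shown here, the exchange of methyl for methoxy, on an aromatic carbon para to a large group, gives a 2.7-fold higher number from compound 2 to compound 4 (0.44 log units; beyond the scatter) and so is not a silent swap, even though it adds only one oxygen to the group. Going by these compounds alone, this is the first pair that differs in one place, and it shows that this position responds to what sits on it, with the 4-methylphenyl compound giving the lower number and so the stronger inhibition. Nothing measured on these two groups bears on this result, so the step stands here as an observation without an explanation.

The compounds shown leave open how other groups at this same place, such as a hydroxyl, a fluorine or an amine, would compare with methyl and methoxy, and so whether the oxygen itself or simply the longer group goes with the higher number. Within the data shown here, they also leave open whether this exchange would give a step of similar size elsewhere on this ring or on the core of compound 1, as only one pair carries it so far.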